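The source may hold more compounds than are shown below. What is called first, only, known or untested is meant among the compounds shown, and "the series" means these compounds.

Within the data shown here, compound 1 `COc1ccc(-c2cc(-c3ccc(Cl)cc3)n(C3C(=O)Nc4ccc(Br)cc43)n2)cc1` is the upper of the two numbers measured so far in a functional assay on cells (Cancer cell lines, Homo sapiens) for cytotoxicity, read by sulforhodamine B assay, with a stated time of 48 h; on this read-out higher numbers stand for weaker inhibition of growth and lower numbers for stronger inhibition of growth: compound 1 gives 30000 nM. Among the measured compounds shown here, its only measured neighbour is compound 2 `COc1ccc(-c2cc(-c3ccc(Cl)cc3)n(C3C(=O)Nc4ccc(Cl)cc43)n2)cc1`, in which chloro replaces bromo on an aromatic carbon; in this assay compound 2 gives 23200 nM, and the step of a 1.3-fold lower number from compound 1 to compound 2 (0.11 log units; within the scatter) lies within the scatter, so the two compounds are not distinguished on these numbers.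

Compound 3 `O=C1Nc2ccc(Br)cc2C1n1nc(-c2ccc3ccccc3c2)cc1-c1ccc(Cl)cc1` differs from compound 1 in another part of the molecule: naphthalen-2-yl in place of 4-methoxyphenyl on an aromatic carbon. For the measured compounds named here, no measured step touches this position, so neither of the two numbers known speaks to the change directly; the only measured step, from compound 1 to compound 2, concerns a halogen elsewhere and was within the scatter. With nothing to indicate a direction, the expectation for compound 3 is no step beyond the scatter, so that a 1.2-fold lower number from compound 1 to compound 3 (0.08 log units; within the scatter) is expected. On that basis compound 3 is estimated at 25000 nM in this assay, with a range from 8000 nM to 80000 nM.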

Compound 3, concentration for total growth inhibition: 10000 nM
The estimate for compound 3 lay 2.5-fold (0.40 log units) above the measured number; low and high end bracket the measured number.
By their numbers in this assay, from the lowest: compound 3; then compounds 2 and 1 (each within the scatter of the next).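

Among the compounds shown, this position on the five-membered aromatic ring with 2 nitrogen is the only one where a change separates two compounds in this assay: naphthalen-2-yl in place of 4-methoxyphenyl gives a 3.0-fold lower number from compound 1 to compound 3 (0.48 log units; beyond the scatter). The step is modest, but the position responds to the aryl group on it, whereas the halogen change gave a 1.3-fold lower number from compound 1 to compound 2 (0.11 log units; within the scatter). No measurement at hand explains the step.

The compounds shown do not separate the second six-membered aromatic ring from the loss of the methoxy oxygen, since both enter with this one change; plain phenyl or 4-hydroxyphenyl at this position would bear on that. Also open, on these data alone, is whether the same change gives a similar step with chloro in place of bromo on the core.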